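Trifluoromethylphenyl for fluorophenyl in compound 4

The source may hold more compounds than are shown below. What is called first, only, known or untested is meant among the compounds shown, and "the series" means these compounds.

In a functional assay on DU-145 cells (Homo sapiens) for inhibition (on this read-out higher numbers stand for weaker inhibition and lower numbers for stronger inhibition), compound 3 `Oc1ccc(-c2cc(-c3cccc(F)c3)cc(-c3ccc(O)cc3)n2)cc1` gives 9290 nM, the lowest of the two numbers shown. Compound 1 `Oc1cccc(-c2cc(-c3ccccc3F)cc(-c3ccccc3O)n2)c1` gives 35600 nM in this assay. Compound 2 `Oc1ccc(-c2cc(-c3cccc(F)c3)cc(-c3ccccc3O)n2)cc1` gives only a limit, > 50000 nM, as shown by the limit of > 50000 nM in this assay, at which 1 of the 3 values shown sits. Among the compounds with values here, the single measured step, an at least 5.3-fold lower number from compound 2 to compound 3 (0.73 log units; beyond the scatter), concerns the hydroxyphenyl groups and not the fluorinated ring. Compound 4 `Oc1ccc(-c2cc(-c3ccc(C(F)(F)F)cc3)cc(-c3ccc(O)cc3)n2)cc1` differs from compound 3 by 4-(trifluoromethyl)phenyl in place of 3-fluorophenyl on an aromatic carbon. Within the data shown here, no measured step bears on this change, so no step beyond the scatter is expected in this assay. The expected step is a 1.0-fold higher number from compound 3 to compound 4 (0.01 log units; within the scatter). Compound 4 is therefore estimated at 9500 nM, in the range from 3000 nM to 30000 nM.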

Compound 4, half-maximal inhibitory concentration: > 50000 nM
Compound 4: no number, only a limit (the forecaster's own chance of this, stated with the estimate: 10%); middle value at least 5.2-fold (0.72 log units) away from the limit.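

The aryl group opposite the ring nitrogen is not a silent position: 4-(trifluoromethyl)phenyl in place of 3-fluorophenyl gives an at least 5.3-fold higher number from compound 3 to compound 4 (0.73 log units; beyond the scatter) in this assay. Within the data shown here, until now, the only measured step concerned the hydroxyphenyl groups, so this is the first read on this site. The result for compound 4 is a limit and not a number, so the full size of the step cannot be read: the limit of > 50000 nM in this assay, at which 2 of the 4 values shown sit.

On these data alone, the change swaps both the substituent and its place on the phenyl ring, and which of the two counts remains open. Also open, as far as these compounds go, is how an amine or a carboxylic acid on this phenyl ring would compare with the 3-fluorophenyl of compound 3.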